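Methoxy-chloro core: amide to carbonyl-linked amino analogue

The source may report more compounds than this note shows. Statements on the series, on what has been measured and on what is new or still open speak of the compounds shown alone.

Measured so far in a functional assay on 786-0 cells (Homo sapiens) for inhibition, read by sulforhodamine B assay, with a stated time of 48 h; on this read-out lower numbers stand for higher toxicity in this test and higher numbers for lower toxicity in this test:
- compound 1, `O=C(Nc1cccc(-n2cc(-c3ccncc3)c(-c3ccc(Cl)c(O)c3)n2)c1)Nc1cccc(C(F)(F)F)c1`, > 32500 nM (a limit of the assay)
- compound 2, `COc1cc(-c2nn(-c3cccc(NC(=O)c4cccc(C(F)(F)F)c4)c3)cc2-c2ccncc2)ccc1Cl`, > 50000 nM (a limit of the assay)
- compound 3, `O=C(Nc1cccc(-n2cc(-c3ccncc3)c(-c3ccc(Cl)c(O)c3)n2)c1)Nc1ccc(Cl)c(Cl)c1`, > 32500 nM (a limit of the assay)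

Among the measured compounds shown here, compound 2 stands only at a limit in this assay; the other two values shown are limits as well, so no compound in the set has a numerical reading. The pair of compound 1 and compound 3 gives a step that the two limits leave unreadable from compound 1 to compound 3, and this step is unreadable because both ends sit at the limit of > 32500 nM in this assay, at which 2 of the 3 values shown sit. Compound 2 sits at the limit of > 50000 nM in this assay, at which 1 of the 3 values shown sits.

Compound 4, `COc1cc(-c2nn(-c3cccc(NC(=O)Nc4cccc(C(F)(F)F)c4)c3)cc2-c2ccncc2)ccc1Cl`, differs from compound 2 by (3-(trifluoromethyl)phenyl)amino in place of 3-(trifluoromethyl)phenyl on a carbonyl carbon. For the measured compounds named here, compound 1 and compound 3 already carry this same carbonyl-linked amino arrangement on the related hydroxy core and both stay at their limit, so none of the measured steps points to a readable gain in toxicity from this change. The expectation for the step from compound 2 to compound 4 is therefore a step that the limit leaves unreadable from compound 2 to compound 4, essentially none beyond the scatter. Compound 4 is estimated at 60000 nM, with a range from 25000 nM to 150000 nM, and most likely the assay again reports only a limit.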

Compound 4, concentration lethal to 50% of the cells: > 50000 nM
Compound 4 gave a limit, no number; the forecaster's own chance of this, stated with the estimate: 85%; the middle value is on the limit's open side.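

Among the compounds shown here, compound 2, compound 1 and compound 4 give only limits of the assay in this assay, so no step among them can be read. The compounds shown leave open whether any member of this series gives a numerical reading in this test.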